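The source may hold more compounds than are shown below. What is called first, only, known or untested is meant among the compounds shown, and "the series" means these compounds.

In an ADME assay on MT4 cells (Homo sapiens) for cytotoxicity, read by MTT assay, with a stated time of 4 days (a higher number here means that more compound is tolerated, a lower number that less compound is tolerated), compound 3 (`Nc1ccc2oc(-c3ccc(F)cc3)c(O)c(=O)c2c1`) gives 92600 nM as the second highest of three measured numbers. Compound 2 (`Nc1ccc2oc(-c3ccccc3)c(O)c(=O)c2c1`) stands higher with 217000 nM and compound 1 (`CC(=O)Nc1ccc2oc(-c3ccc(C(F)(F)F)cc3)c(O)c(=O)c2c1`) stands lower with 7300 nM on the same scale. Compound 4 (`Nc1ccc2oc(-c3ccc(C(F)(F)F)cc3)c(O)c(=O)c2c1`) has not yet been measured. Its change from compound 3 is trifluoromethyl in place of fluoro on an aromatic carbon and the rest of the structure stays the same. Going by the values given here, one measured step bears on this change: a 2.3-fold lower number from compound 2 to compound 3 (0.37 log units; beyond the scatter) came with fluoro in place of hydrogen on an aromatic carbon, a modest move beyond the scatter. Among the compounds with values here, no measured step exchanges fluoro for trifluoromethyl directly. Within the data shown here, compound 1 is the only measured compound that carries trifluoromethyl, and compound 1 at 7300 nM has the lowest of the three numbers. It also differs from compound 4 elsewhere on the core, so it is only a loose guide. Taken together, these two observations point downward, and the expected step is a 2.6-fold lower number from compound 3 to compound 4 (0.42 log units; beyond the scatter) in the same direction as the step from hydrogen to fluoro, and of similar or somewhat larger size. For compound 4 the estimated value is 35000 nM with an expected range from 12000 nM to 90000 nM in this read-out.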

Compound 4, half-maximal cytotoxic concentration: 3900 nM
The estimate for compound 4 lay 9.0-fold (0.95 log units) above the measured number, and the stated range ends above it.
By their numbers in this assay, from the lowest: compounds 4 and 1 (each within the scatter of the next); then compound 3; then compound 2.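

The direct exchange on the aromatic carbon para to a large group shows that this position responds far more steeply in this assay than the first change suggested: trifluoromethyl in place of fluoro gives a 24-fold lower number from compound 3 to compound 4 (1.38 log units; beyond the scatter), and trifluoromethyl in place of hydrogen gives a 56-fold lower number from compound 2 to compound 4 (1.75 log units; beyond the scatter), whereas fluoro in place of hydrogen gave only a 2.3-fold lower number from compound 2 to compound 3 (0.37 log units; beyond the scatter). At the nitrogen on the aromatic ring, hydrogen in place of acetyl gives a 1.9-fold lower number from compound 1 to compound 4 (0.27 log units; within the scatter), so with trifluoromethyl in place this pair is not separated in this assay, and the low number of compound 1 now reads as shared with compound 4 rather than tied to its acetyl group. Nothing available explains why the step to trifluoromethyl is so large.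

The compounds shown leave open whether other groups on this aromatic carbon, such as chloro, methyl, methoxy or nitrile, would fall near the numbers for fluoro or for trifluoromethyl. They also leave open whether acetyl on the nitrogen would stay as silent with hydrogen or fluoro on that carbon, and whether a longer acyl chain there would behave as acetyl does.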